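Cap and chain change from compound 1 to compound 4

This account rests on a few compounds, and the source may have more. Where it says the series, first, only, none or still open, it means among the compounds named here.

Measured compounds:
compound 1 `O=S(=O)(NCCNc1nccc(-c2c(-c3cccc(F)c3)nc3sccn23)n1)c1ccc(Br)cc1`: 13500 nM
compound 2 `O=C(NCCNc1nccc(-c2c(-c3cccc(F)c3)nc3sccn23)n1)c1c(F)cccc1F`: 11400 nM
compound 3 `COc1ccc(S(=O)(=O)NCCCNc2nccc(-c3c(-c4cccc(F)c4)nc4sccn34)n2)cc1`: 8980 nM

In a functional assay on SK-MEL-28 cells (Homo sapiens) for cytotoxicity, read by MTT assay (on this read-out lower numbers stand for stronger inhibition and higher numbers for weaker inhibition), compound 1 holds the highest of the three numbers. Its nearest neighbour is compound 2, the step being a 1.2-fold lower number from compound 1 to compound 2 (0.07 log units; within the scatter). Within the data shown here, compound 3 gives 8980 nM, which lies within the usual scatter of the number for compound 1; no single-point step connects these two, as they differ in both the end group and the chain.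

Compound 4 `O=C(NCCCNc1nccc(-c2c(-c3cccc(F)c3)nc3sccn23)n1)c1ccc(F)cc1` is not yet measured. It differs from compound 1 as follows: (((4-fluorophenyl)carbonyl)amino)methyl in place of ((4-bromophenyl)sulfonyl)amino on a saturated chain carbon, two bonds along the chain from a nitrogen on an aromatic ring

The change combines the carbonyl-for-sulfonyl exchange seen in the step from compound 1 to compound 2, which stayed within scatter, with a chain one carbon longer, as in compound 3, whose number also sits within scatter of compound 1. Nothing in the three measured values points to a step beyond scatter in this assay, though both comparisons lean toward a slightly lower number. Compound 4 is therefore expected to give 9000 nM, with a range of 4000 nM to 20000 nM. The expected step is a 1.5-fold lower number from compound 1 to compound 4 (0.18 log units; within the scatter).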

Compound 4, half-maximal inhibitory concentration: > 20000 nM
Compound 4: only a limit was reported; the forecaster's own chance of this, stated with the estimate: 10%; middle value at least 2.2-fold (0.34 log units) from the limit.
By their numbers in this assay, from the lowest: compounds 3, 2 and 1 (each within the scatter of the next). At a limit, above all of these: compound 4.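

In this assay compound 4 is reported only as a limit, not a number: the limit of > 20000 nM in this assay, at which 1 of the 4 values shown sits. Among these compounds, the sulfonyl-to-carbonyl exchange gave a 1.2-fold lower number from compound 1 to compound 2 (0.07 log units; within the scatter), whereas with the chain of compound 3 the cap change gives an at least 2.2-fold higher number from compound 3 to compound 4 (0.34 log units; beyond the scatter), the first step printed as beyond the scatter. The other two steps, an at least 1.4-fold higher number from compound 1 to compound 4 (0.17 log units; that floor lies within the scatter) and an at least 1.7-fold higher number from compound 2 to compound 4 (0.24 log units; that floor lies within the scatter), have floors within the scatter, and their full size cannot be read from a limit.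

The cap change from compound 3 to compound 4 alters both the carbonyl or sulfonyl link and the ring substituent, and the compounds shown do not separate the two. A (4-fluorophenyl)sulfonyl or (4-methoxyphenyl)carbonyl cap on the same chain would test each part alone.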